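A few compounds are considered here, and "the series" means these few. Any claim that something is new, unique, unknown or untested is made for them only; others in the source may bear on it.

In a functional assay on BXPC-3 cells (Homo sapiens) for antiproliferative activity, read by MTT assay, with a stated time of 24 h (on this read-out higher numbers stand for weaker inhibition and lower numbers for stronger inhibition), compound 1 `CCn1c(C(=O)NCC(=O)OC)ccc1C(CC)(CC)c1ccc(OCS(=O)(=O)c2ccccc2)c(C)c1` gives 20000 nM and compound 2 `CCn1c(C(=O)N[C@@H](C)C(=O)O)ccc1C(CC)(CC)c1ccc(OCS(=O)(=O)c2ccccc2)c(C)c1` gives 20800 nM, so compound 2 stands level with compound 1 within the scatter. Compound 3 `CCn1c(C(=O)N[C@H](C)C(=O)O)ccc1C(CC)(CC)c1ccc(OCS(=O)(=O)c2ccccc2)c(C)c1` relates to compound 2 thus: the two compounds have the same atoms and bonds and differ only in configuration as drawn: 1 of 1 stereo elements differ; a stereocentre at a saturated chain carbon is drawn S in compound 2 and R in compound 3. A stereocentre at a saturated chain carbon is drawn S in compound 2 and R in compound 3. Within the data shown here, no measured step changes configuration alone. Among the measured compounds shown here, the one step bearing on it, at the amide-type nitrogen, is a 1.0-fold higher number from compound 1 to compound 2 (0.02 log units; within the scatter), which lies within the scatter. No step beyond the scatter is therefore expected, and the estimated move is a 1.0-fold lower number from compound 2 to compound 3 (0.02 log units; within the scatter). Compound 3 is expected at 20000 nM, with an estimated range of 11000 nM to 38000 nM.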

Compound 3, half-maximal inhibitory concentration: 20100 nM
Compound 3: middle estimate off by 1.0-fold (0.00 log units), on the low side; low and high end bracket the measured number.
By their numbers in this assay, from the lowest: compounds 1, 3 and 2 (each within the scatter of the next).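

In this assay, configuration at the saturated chain carbon now has a direct reading, with a 1.0-fold lower number from compound 2 to compound 3 (0.01 log units; within the scatter). The two drawn forms of the 1-carboxyethyl group therefore stand level in this pair, which isolates that stereocentre: the fact that compounds 2 and 3 differ only in the configuration as drawn. The R form also stands level with the (methoxycarbonyl)methyl compound, with a 1.0-fold higher number from compound 1 to compound 3 (0.00 log units; within the scatter), so the earlier level result does not hold for the S form alone.

As far as these compounds go, whether a longer chain on the 1-carboxyethyl group, or an amine in place of its carboxylic acid, would separate the two configurations remains open.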